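Swapping the amide arm for a pyridine ring

The compounds below may be only part of what the source reports. "The series", "measured", "known", "first", "only" and "open" are said of these compounds alone.

Of the compounds shown here, three built on a shared core have been measured in an assay on HeLa cells for inhibition of Kinesin-like protein KIF15 (Homo sapiens), read by microscopy, with stated times of 2 s and 20 s, tested at 750 nM; on this read-out higher numbers stand for more inhibition at the one concentration tested (going by the name of the read-out) and lower numbers for less inhibition. Compound 1 `O=C1Nc2ccc(C(=O)c3ccco3)cc2/C1=C/c1ccc(O)nc1` gives 26.5%. Among the compounds with values here, compound 2 `COc1ccc(/C=C2\C(=O)Nc3ccc(C(=O)c4ccco4)cc32)cc1Br` gives 2.3%, and the single measured step, a number 24.2 percentage points lower from compound 1 to compound 2 (beyond the scatter), is the only change whose size is known so far. Compound 3 `O=C1Nc2ccc(C(=O)NCc3ccccc3)cc2/C1=C/c1cc(Cl)c(O)c(Cl)c1` gives -24%, the lowest of the three numbers, with compound 2 nearest to it and compound 1 furthest away. Compound 4 `O=C1Nc2ccc(-c3ccccn3)cc2/C1=C/c1cc(Cl)c(O)c(Cl)c1` has not yet been measured. It differs from compound 3 at one place: pyridin-2-yl in place of benzylcarbamoyl on an aromatic carbon. Within the data shown here, the one measured step changes a different part of the molecule, so it does not bear on this change. Among the measured compounds shown here, compounds 1 and 2 carry another group at the same aromatic carbon, but no step from either of them to compound 3 is known. With so little to lean on, only a small rise is expected, a number 19 percentage points higher from compound 3 to compound 4 (beyond the scatter), inside a wide range. Compound 4 is therefore estimated at -5%, expected to fall between -30% and 20%.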

Compound 4, a percentage reported as inhibition, at one concentration (the size of the read-out at that concentration, not a potency): 7.3%
The estimate for compound 4 lay 12.3 percentage points below the measured number; measured number inside the range.
By their numbers in this assay, from the lowest: compound 3; then compounds 2 and 4 (each within the scatter of the next); then compound 1.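

In this assay, within the data shown here, this is the first measured change at this aromatic carbon, and a number 31.3 percentage points higher from compound 3 to compound 4 (beyond the scatter) shows that the group held there can shift the read-out well beyond the scatter while the rest of the molecule stays the same. The swap removes benzylcarbamoyl, with its 10 heavy atoms, its hydrogen-bond donor and its double bond outside the aromatic rings, and puts in pyridin-2-yl, with 6 heavy atoms and no donor, so several features change at once. No measurement is available to explain the rise.

Which of those features matters remains open, since the two groups differ in size, donor count and ring nitrogen together. A plain phenyl ring or a shorter methylcarbamoyl group at this carbon would begin to pull these features apart.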